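Swapping a urea for a carbamate on the shared core

This account rests on a few compounds, and the source may have more. Where it says the series, first, only, none or still open, it means among the compounds named here.

Of the compounds shown here, three sharing one core have been measured in a functional assay on A549 cells (Homo sapiens) for cytotoxicity, read by MTT assay; on this read-out lower numbers stand for stronger inhibition and higher numbers for weaker inhibition. Compound 1 `CCc1cc(S(=O)(=O)N2C[C@H](c3ccccc3)NC2=O)ccc1NC(=O)c1ccc(N)cc1` gives 220 nM. Compound 2 `CCOC(=O)Nc1ccc(S(=O)(=O)N2C[C@H](c3ccccc3)NC2=O)cc1Cl` gives 20 nM, the lowest of the three. Compound 3 `CCc1cc(S(=O)(=O)N2C[C@H](c3ccccc3)NC2=O)ccc1NC(=O)NC(C)C` gives 100 nM, the second highest number, sitting between compound 1 and compound 2. Among the measured compounds shown here, the one measured step touching compound 3 is the change a 2.2-fold lower number from compound 1 to compound 3 (0.34 log units; beyond the scatter), a modest move. Compound 4 `CCOC(=O)Nc1ccc(S(=O)(=O)N2C[C@H](c3ccccc3)NC2=O)cc1CC` is not yet measured. It differs from compound 3 by ethoxy in place of isopropylamino on a carbonyl carbon. For the measured compounds named here, no measured step shows this exact change, so no direct guide exists. Compound 2, however, already carries the (ethoxycarbonyl)amino group and its value of 20 nM is the lowest of the set, which suggests that compound 4 may land closer to compound 2 than to compound 3. The step is therefore expected to be a 2.9-fold lower number from compound 3 to compound 4 (0.46 log units; beyond the scatter), a lowering of the number. Compound 4 is estimated at 35 nM, with a range from 12 nM to 100 nM, in this assay.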

Compound 4, half-maximal inhibitory concentration: 60 nM
The estimate for compound 4 lay 1.7-fold (0.23 log units) below the measured number; the measured number falls inside the stated range.
By their numbers in this assay, from the lowest: compound 2; then compounds 4 and 3 (each within the scatter of the next); then compound 1.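

In this assay, the step with ethoxy in place of isopropylamino on a carbonyl carbon is a 1.7-fold lower number from compound 3 to compound 4 (0.22 log units; within the scatter), so with the ethyl group in place, the carbamate and the urea cannot be told apart here. Ethoxy in place of 4-aminophenyl at that carbonyl carbon gives a clearer step, a 3.7-fold lower number from compound 1 to compound 4 (0.56 log units; beyond the scatter), while ethyl in place of chloro on an aromatic carbon, with the (ethoxycarbonyl)amino group held fixed, gives a 3.0-fold higher number from compound 2 to compound 4 (0.48 log units; beyond the scatter), showing that this second position also moves the number beyond the scatter. No supporting measurement explains these differences.

Still open, going by these compounds, is how a bromo or methyl group on that aromatic carbon would compare with chloro and ethyl. Also open, on these data alone, is whether a longer chain, such as butoxy, on the carbonyl carbon would keep the number near that of ethoxy.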